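From 3-Chlorophenyl to (4-Methoxyphenyl)carbonyl: One Predicted Step

A few compounds are considered here, and "the series" means these few. Any claim that something is new, unique, unknown or untested is made for them only; others in the source may bear on it.

Measured compounds:
compound 1, `CCCCCCCCS(=O)(=O)Nc1cc(-c2ccc(CCCC)cc2)ccc1C(=O)O`: 15700 nM
compound 2, `CCCCCCCCS(=O)(=O)Nc1cc(-c2ccccc2-c2ccccc2)ccc1C(=O)O`: 17100 nM
compound 3, `CCCCCCCCS(=O)(=O)Nc1ccc(-c2cccc(Cl)c2)cc1C(=O)O`: 8900 nM

The three compounds share one core, visible beside each structure, and were all tested in an assay on mitochondria (strain BALB/c) for inhibition of glycerol-3-phosphate acyltransferase 1, mitochondrial (Mus musculus), read by scintillation counting, with a stated time of 10 min; a higher number here means a weaker inhibitor, a lower number a stronger inhibitor. Compound 3 gives 8900 nM, the lowest of the three numbers, yet both compound 1 with 15700 nM and compound 2 with 17100 nM lie within the scatter of it, so no order among the three can be claimed and none can be called the strongest.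

Compound 4, `CCCCCCCCS(=O)(=O)Nc1ccc(C(=O)c2ccc(OC)cc2)cc1C(=O)O`, has not yet been measured. It differs from compound 3 in one place: (4-methoxyphenyl)carbonyl in place of 3-chlorophenyl on an aromatic carbon. Among the compounds with values here, no measured pair shows what this kind of exchange does in this assay, so the expectation rests on the three numbers alone, which sit close together. The step is expected to be small, at most about the scatter, with no clear direction: a 1.3-fold higher number from compound 3 to compound 4 (0.13 log units; within the scatter) is the expected step from compound 3 to compound 4. Compound 4 is therefore estimated at 12000 nM in this assay, with a range from 4000 nM to 40000 nM.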

Compound 4, half-maximal inhibitory concentration: 44300 nM
Compound 4: the middle estimate sits 3.7-fold (0.57 log units) below what was measured; measured number above the stated range.
By their numbers in this assay, from the lowest: compounds 3, 1 and 2 (each within the scatter of the next); then compound 4.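

In this assay, within the data shown here, (4-methoxyphenyl)carbonyl in place of 3-chlorophenyl gives a 5.0-fold higher number from compound 3 to compound 4 (0.70 log units; beyond the scatter) and so shows that this position, meta to a carboxy group and para to a large group, responds to what is placed on it, which the earlier compounds, differing from one another in more than one place, could not show. The entering group keeps one six-membered aromatic ring of carbon only but adds a carbonyl and a methoxy oxygen, and this single pair cannot separate their shares in the step. Nothing at hand explains the step.

On these data alone, what a plain phenylcarbonyl group or a 4-methoxyphenyl group would do at this position stays open, and with it whether the carbonyl or the methoxy group matters more. As far as these compounds go, the outcome with an amine or a hydroxy group at the same place stays open too.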